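A few compounds are considered here, and "the series" means these few. Any claim that something is new, unique, unknown or untested is made for them only; others in the source may bear on it.

In a functional assay on MDA-MB-231 cells (Homo sapiens) for antiproliferative activity, read by MTT assay, with a stated time of 48 h (on this read-out lower numbers stand for stronger inhibition of growth and higher numbers for weaker inhibition of growth), compound 1 `COc1ccc(/C=C2\Cc3c(cc(OC)c(OC)c3OC)C2=O)cc1` gives 429 nM. Compound 2 `COc1ccc(/C=C2\Cc3c(cc(OC)c(OC)c3OC)C2=O)cc1N` arises from compound 1 through (amino in place of hydrogen on an aromatic carbon), and in this assay compound 2 gives 485 nM, so that the step is a 1.1-fold higher number from compound 1 to compound 2 (0.05 log units; within the scatter). Compound 3 `COc1ccc(/C=C2\Cc3cc(OC)c(OC)c(OC)c3C2=O)cc1` contains the same atoms as compound 1 joined differently; the difference between the two cores is not broken down here. In this assay compound 3 reaches only the limit of > 10000 nM, which is a limit of the assay and not a number, at which (the limit of > 10000 nM in this assay, at which 1 of the 3 values shown sits). Compound 4 `COc1ccc(/C=C2\Cc3cc(OC)c(OC)c(OC)c3C2=O)cc1N` follows from compound 3 through (amino in place of hydrogen on an aromatic carbon), the same change as that from compound 1 to compound 2, with the same surroundings at its place. Because a 1.1-fold higher number from compound 1 to compound 2 (0.05 log units; within the scatter) lay within the scatter and compound 3 sits at a limit, compound 4 is expected to stay close to that limit, an estimated step that the limit leaves unreadable from compound 3 to compound 4. Compound 4 is therefore estimated at 15000 nM, between 5000 nM and 50000 nM, and will most likely again be reported only as a limit in this assay.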

Compound 4, concentration for 50% growth inhibition: > 10000 nM
Compound 4: only a limit was reported; the forecaster's own chance of this, stated with the estimate: 70%; the middle value is on the limit's open side.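

No step can be read between compound 3 and compound 4 in this assay, because each of them is reported only as a limit and not as a number: the limit of > 10000 nM in this assay, at which 2 of the 4 values shown sit.

The compounds shown leave open whether amino in place of hydrogen on an aromatic carbon changes growth inhibition at all on the core of compound 3.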